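The source may report more compounds than this note shows. Statements on the series, on what has been measured and on what is new or still open speak of the compounds shown alone.

Working notes on the series.

Among the compounds with values here, compound 2 `O=C(O)c1ccccc1-c1ccc(CCc2ncc(CC3CCC3)[nH]2)cc1` in an in vitro functional assay on cells for agonist activity at Bombesin receptor subtype-3 (Homo sapiens), read by luminescence and calcium flux (on this read-out higher numbers stand for an effect only at larger amounts of compound and lower numbers for an effect already at smaller amounts), gives 588 nM, the higher of the two numbers so far. Within the data shown here, its nearest neighbour is compound 1 `O=C(O)c1ccccc1-c1ccc(CCc2ncc(CC3CCCCC3)[nH]2)cc1`, which in this assay gives 41 nM; the step of a 14-fold higher number from compound 1 to compound 2 (1.16 log units; beyond the scatter) is the only measured step and it is large, with the smaller ring giving the higher number.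

Compound 3 `O=C(O)c1ccccc1-c1ccc(CCc2ncc(C3CCCCC3)[nH]2)cc1` is not yet measured. It differs from compound 2 by cyclohexyl in place of cyclobutylmethyl on an aromatic carbon. Among the measured compounds shown here, the one measured step bears on this change insofar as it exchanges a four-membered ring for a six-membered ring, the reverse of the direction that gave a 14-fold higher number from compound 1 to compound 2 (1.16 log units; beyond the scatter). For the measured compounds named here, no measured pair isolates the loss of the chain carbon between the ring and the aromatic carbon, so that part of the change is uncovered. A lower number than compound 2 is therefore expected for compound 3, the step of a 5.9-fold lower number from compound 2 to compound 3 (0.77 log units; beyond the scatter) being estimated as a return part way toward compound 1. Compound 3 is estimated at 100 nM in this assay, with a range from 30 nM to 400 nM.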

Compound 3, half-maximal effective concentration: 375 nM
Estimate against measurement, compound 3: 3.8-fold (0.57 log units) below, within the range that was stated.
By their numbers in this assay, from the lowest: compound 1; then compounds 3 and 2 (each within the scatter of the next).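

In this assay, the new result shows that a six-membered ring on this aromatic carbon does not by itself carry the low number of compound 1: with cyclohexyl in place of cyclohexylmethyl, the number does not hold (a 9.1-fold higher number from compound 1 to compound 3 (0.96 log units; beyond the scatter)). Cyclohexyl and cyclobutylmethyl at this position, on an aromatic carbon of the five-membered aromatic ring with 2 nitrogen, cannot be told apart in this read-out (a 1.6-fold lower number from compound 2 to compound 3 (0.20 log units; within the scatter)). Of the three compounds, only compound 1, with cyclohexylmethyl, stands apart from the others, and its steps to both are beyond the scatter, so the earlier ring-size step (a 14-fold higher number from compound 1 to compound 2 (1.16 log units; beyond the scatter)) is now seen to depend on more than the ring alone. No measurement at hand gives a reason for these numbers.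

The compounds shown leave open how the number moves with a longer chain at this position, such as cyclohexylethyl, and whether cyclopentylmethyl gives a number nearer to compound 1 or to compound 2. They also leave open whether benzyl, with an aromatic ring on the same chain carbon, would keep the number of compound 1.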